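The source may report more compounds than this note shows. Statements on the series, on what has been measured and on what is new or still open speak of the compounds shown alone.

The series shares one core, seen in compound 1 `Fc1cc(-c2nnc3n2N=C(c2ccc(Cl)cc2)CS3)c(Cl)cc1Cl` and compound 2 `Fc1cc(-c2nnc3n2N=C(c2ccc(Cl)cc2Cl)CS3)c(Cl)cc1Cl`. In a functional assay on SNB-75 cells (Homo sapiens) for antiproliferative activity, read by sulforhodamine B assay, with a stated time of 48 h (a higher number here means a weaker inhibitor of growth, a lower number a stronger inhibitor of growth), compound 1 gives 3370 nM. Compound 2 sits at the limit of > 100000 nM in this assay, at which 1 of the 2 values shown sits. In this assay compound 2 gives > 100000 nM, a limit rather than a number. The single measured step, an at least 29-fold higher number from compound 1 to compound 2 (1.47 log units; beyond the scatter), thus has no exact size, but on the numbers shown compound 2 is the weaker of the pair. Compound 3 `Fc1cc(C2=Nn3c(nnc3-c3cc(F)c(Cl)cc3Cl)SC2)c(Cl)cc1Cl` differs from compound 2 by fluoro in place of hydrogen on an aromatic carbon. For the measured compounds named here, no measured step concerns fluoro; the one step in hand, chloro in place of hydrogen, was large and ran toward weaker growth inhibition, and compound 2 already stands at the limit. Compound 3 is therefore expected to stay near that limit, with a number no higher from compound 2 to compound 3 (the limit leaves the size open) understood as no step beyond the scatter. The estimate for compound 3 in this assay is 100000 nM, within 30000 nM to 300000 nM, most likely again reported only as a limit.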

Compound 3, concentration for 50% growth inhibition: 26200 nM
For compound 3 the middle estimate is 3.8-fold (0.58 log units) above the measured one; measured number below the stated range.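

In this assay, the change from 2,4-dichlorophenyl to 2,4-dichloro-5-fluorophenyl gives an at least 3.8-fold lower number from compound 2 to compound 3 (0.58 log units; beyond the scatter), so this position can offset part of the loss that came with the added chloro. The offset is only partial, since 2,4-dichloro-5-fluorophenyl in place of 4-chlorophenyl still gives a 7.8-fold higher number from compound 1 to compound 3 (0.89 log units; beyond the scatter). The fluoro step has no exact size because compound 2 is known only as a limit: the limit of > 100000 nM in this assay, at which 1 of the 3 values shown sits.

From the compounds shown here alone, whether an amine or a methoxy group at this position would act as fluoro does remains open. Also open, going by these compounds, is what fluoro at the same position would do on the 4-chlorophenyl group of compound 1, without the added chloro.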